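Swapping a dichlorobenzyl for a fluorobenzyl on a shared core

The source may report more compounds than this note shows. Statements on the series, on what has been measured and on what is new or still open speak of the compounds shown alone.

Three compounds carry the same core. Compound 1 `Nc1cc(N)c2nc(-c3ccccc3)c(NCc3ccc(Cl)c(Cl)c3)nc2c1` is tested in a functional assay on NCI-H23 cells (Homo sapiens) for inhibition, read by sulforhodamine B assay, with a stated time of 48 h (a higher number here means that more compound is tolerated, a lower number that less compound is tolerated), where compound 1 gives 55000 nM. Compound 2 `CCOC(=O)[C@H](CCC(=O)O)NC(=O)c1ccc(Sc2nc3cc(N)cc(N)c3nc2-c2ccccc2)cc1` gives 95500 nM, and compound 3 `CCOC(=O)[C@H](CCC(=O)O)NC(=O)c1ccc(Oc2nc3cc(N)cc(N)c3nc2-c2ccccc2)cc1` gives 60300 nM; all three numbers lie within the usual scatter of one another, so compound 1 is not set apart from the other two.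

Compound 4 `Nc1cc(N)c2nc(-c3ccccc3)c(NCc3ccc(F)cc3)nc2c1` differs from compound 1 only in the change (4-fluorophenyl in place of 3,4-dichlorophenyl on a saturated chain carbon bound to a nitrogen on an aromatic ring). Within the data shown here, no measured pair shows a step of this kind, so the direction is open, and no step beyond the scatter is expected. Compound 4 is therefore expected to give about 65000 nM in this assay, within a range from 28000 nM to 150000 nM, an expected step of a 1.2-fold higher number from compound 1 to compound 4 (0.07 log units; within the scatter).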

Compound 4, concentration lethal to 50% of the cells: 8910 nM
Estimate against measurement, compound 4: 7.3-fold (0.86 log units) above, and the stated range ends above it.
By their numbers in this assay, from the lowest: compound 4; then compounds 1, 3 and 2 (each within the scatter of the next).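

In this assay the change from 3,4-dichlorobenzyl to 4-fluorobenzyl gives a 6.2-fold lower number from compound 1 to compound 4 (0.79 log units; beyond the scatter) on the shared core. Among these compounds, this shows that the group on a saturated chain carbon bound to a nitrogen on an aromatic ring does affect the read-out, which the earlier compounds, differing from compound 1 in more than one place, could not show. Nothing at hand explains the step.

The compounds shown do not separate the loss of the two chlorines from the arrival of the fluorine. As far as these compounds go, how a plain benzyl group, or a carboxylic acid on that ring, would read remains open.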